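The source may report more compounds than this note shows. Statements on the series, on what has been measured and on what is new or still open speak of the compounds shown alone.

Compound 1 `CSCn1c(=N)sc2cc(OC(F)(F)F)ccc21` is the starting point of this small set. In a functional assay on the whole organism with Rattus norvegicus as the target (on this read-out lower numbers stand for an effect already at smaller amounts and higher numbers for an effect only at larger amounts of compound), compound 1 gives 3 mg/kg. Compound 2 `C[S+]([O-])Cn1c(=N)sc2cc(OC(F)(F)F)ccc21` differs from it by a group of 3 heavy atoms (1 carbon, 1 oxygen, 1 sulfur; no ring) in place of a group of 2 heavy atoms (1 carbon, 1 sulfur; no ring), on a saturated chain carbon bound to an aromatic nitrogen, and in this assay compound 2 gives 2.3 mg/kg, which amounts to a 1.3-fold lower number from compound 1 to compound 2 (0.12 log units; within the scatter). Compound 3 `CSCCCn1c(=N)sc2cc(OC(F)(F)F)ccc21` carries a different core, and how the two cores differ is 2-(methylsulfanyl)ethyl in place of methylsulfanyl on a saturated chain carbon bound to an aromatic nitrogen. In this assay compound 3 gives 4.2 mg/kg, so that the step is a 1.4-fold higher number from compound 1 to compound 3 (0.15 log units; within the scatter) and, against compound 2, a 1.8-fold higher number from compound 2 to compound 3 (0.26 log units; within the scatter). All three numbers thus lie within the scatter of one another, and none of the three compounds can be called stronger or weaker than the others.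

Compound 4 `C[S+]([O-])CCCn1c(=N)sc2cc(OC(F)(F)F)ccc21` has not been measured in this assay. It differs from compound 3 by a group of 3 heavy atoms (1 carbon, 1 oxygen, 1 sulfur; no ring) in place of a group of 2 heavy atoms (1 carbon, 1 sulfur; no ring), on a saturated chain carbon, three bonds along the chain from an aromatic nitrogen. Within the data shown here, this is the same kind of change as the one from compound 1 to compound 2, but not the same: there the group sat on a saturated chain carbon bound to an aromatic nitrogen, whereas here it sits on a saturated chain carbon, three bonds along the chain from an aromatic nitrogen. Because a 1.3-fold lower number from compound 1 to compound 2 (0.12 log units; within the scatter) stayed within the scatter, the expected step is a 1.3-fold lower number from compound 3 to compound 4 (0.10 log units; within the scatter), also within the scatter, resting only on that single earlier pair. Compound 4 is therefore estimated to give 3.3 mg/kg in this assay. Compound 4 is expected to fall between 1.8 mg/kg and 6.5 mg/kg.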

Compound 4, dose for half-maximal effect: 2.3 mg/kg
The estimate for compound 4 lay 1.4-fold (0.16 log units) above the measured number; the measured number falls inside the stated range.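

The new step is a 1.8-fold lower number from compound 3 to compound 4 (0.26 log units; within the scatter), and in this assay it stands close to the earlier step for the same exchange of methylsulfanyl for the group of 3 heavy atoms, on the shorter chain: the same change on two cores in this assay, a 1.3-fold lower number (0.12 log units; within the scatter) from compound 1 to compound 2 and a 1.8-fold lower number (0.26 log units; within the scatter) from compound 3 to compound 4, 1.4-fold (0.15 log units) apart, within the scatter of two such steps. Compound 4 also lies within the scatter of the other two compounds, with no change at the digits printed from compound 2 to compound 4 (within the scatter) and a 1.3-fold lower number from compound 1 to compound 4 (0.12 log units; within the scatter), so the four compounds cannot be ranked in this assay, and neither the exchange nor the difference in chain length separates them. The two steps therefore show that, on these two cores, the change carries over without a detectable difference, but they do not show that it has a real effect on either core or that its effect is the same on both, as each step rests on a single pair and both stay within the scatter.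

The compounds shown leave open whether a sulfone, an amine or a carboxylic acid at the end of the chain would give a number beyond the scatter of these four. They also leave open whether a longer chain, or a group other than trifluoromethoxy on the shared core, would let the same exchange behave differently from one core to another.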